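The compounds below may be only part of what the source reports. "The series", "measured", "known", "first", "only" and "open" are said of these compounds alone.

Measured so far:
compound 1 `CCCC(Oc1ccc(-n2cc(OC)cn2)cc1)c1ccc(C(=O)NCCC(=O)O)cc1` — > 23000 nM
compound 2 `CCCC(Nc1ccc(-n2cc(C(F)(F)F)cn2)nc1)c1ccc(C(=O)NCCC(=O)O)cc1` — 1300 nM

In a functional assay on cells for antagonist activity at Glucagon receptor (Homo sapiens), read by cAMP accumulation, in the presence of a further agent that is not named here (a higher number here means a weaker inhibitor, a lower number a stronger inhibitor), compound 1 gives only a limit, > 23000 nM, and no number. Its value sits at the limit of > 23000 nM in this assay, at which 1 of the 2 values shown sits. Compound 2 gives 1300 nM in this assay; the two compounds differ at several places at once, so the gap between them is not treated as one step.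

Compound 3 `CCCC(Oc1ccc(-n2cccn2)cc1)c1ccc(C(=O)NCCC(=O)O)cc1` is compound 1 with hydrogen in place of methoxy on an aromatic carbon. Going by the values given here, no single step of this kind has been measured. Since compound 1 stands at a limit, the expectation is that loss of the methoxy group gives no change beyond the scatter in this assay, and that compound 3 may again return only a limit. Compound 3 is estimated at 30000 nM, with a range of 8000 nM to 100000 nM. The expected step that the limit leaves unreadable from compound 1 to compound 3 is accordingly small.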

Compound 3, antagonist equilibrium constant: > 55000 nM
Compound 3 ended at the assay's limit; the forecaster's own chance of this, stated with the estimate: 60%; middle value at least 1.8-fold (0.26 log units) away from the limit.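

Going by these compounds alone, compound 1 and compound 3 both return only limits in this assay, and no step between them can be read. The compounds shown leave open how far hydrogen in place of methoxy on the pyrazole changes inhibitor strength on the core of compound 1.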